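Replacing 3-phenylprop-2-en-1-yl with 4-nitrobenzyl

This account rests on a few compounds, and the source may have more. Where it says the series, first, only, none or still open, it means among the compounds named here.

Of the compounds shown here, three have been measured in a functional assay (B cells) with Mus musculus as the target; on this read-out higher numbers stand for an effect only at larger amounts of compound and lower numbers for an effect already at smaller amounts. Compound 1 (`Nc1nc(O)c2c(n1)n(C1OC(CO)[C@@H](O)[C@H]1O)c(=O)n2C/C=C/c1ccccc1`) gives 103 uM, the highest number of the three. Compound 2 (`C=CCn1c(=O)n([C@@H]2O[C@H](CO)[C@H]3OC(=O)O[C@H]32)c2nc(N)nc(O)c21`) gives 3 uM, and compound 3 (`C=CCn1c(=S)n(C2OC(CO)[C@@H](O)[C@H]2O)c2nc(N)nc(O)c21`) gives 1 uM. Both numbers lie well beyond the scatter below that of compound 1. Neither compound 2 nor compound 3 carries the 3-phenylprop-2-en-1-yl group of compound 1, but each differs from compound 1 in more than one place. No single change can be read from these gaps.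

Compound 4 (`Nc1nc(O)c2c(n1)n(C1OC(CO)[C@@H](O)[C@H]1O)c(=O)n2Cc1ccc([N+](=O)[O-])cc1`) has not yet been measured. It keeps the core of compound 1 and changes one group: 4-nitrophenyl in place of 2-phenylethenyl on a saturated chain carbon bound to an aromatic nitrogen. Among the measured compounds shown here, no measured pair isolates this change, and the expectation starts from compound 1 at 103 uM. A small move toward a lower number is expected in this assay, possibly none beyond the scatter. The expected step is a 1.7-fold lower number from compound 1 to compound 4 (0.23 log units; within the scatter), and this estimate is uncertain. For compound 4 the estimated value is 60 uM, with an expected range of 15 uM to 250 uM.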

Compound 4, concentration for half-maximal effect: 40 uM
Estimate against measurement, compound 4: 1.5-fold (0.18 log units) above, and the stated range covers the measured number.
By their numbers in this assay, from the lowest: compound 3; then compound 2; then compound 4; then compound 1.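

In this assay, among the compounds shown here, replacing 3-phenylprop-2-en-1-yl with 4-nitrobenzyl on the shared core gives a 2.6-fold lower number from compound 1 to compound 4 (0.41 log units; beyond the scatter), the first change that can be read at a single place. The group on the saturated chain carbon bound to an aromatic nitrogen can thus be exchanged with the six-membered aromatic ring retained and hydrogen-bond acceptors added, and the number moves only modestly, though beyond the usual scatter. Nothing available explains this step.

Still open, on these data alone, is how the number responds to a plain benzyl group or a 4-aminobenzyl group at this place. Those two groups would help show whether the step follows the nitro group or the loss of the chain double bond.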